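The source may hold more compounds than are shown below. What is called first, only, known or untested is meant among the compounds shown, and "the series" means these compounds.

Measured in a functional assay on HL-60 cells (Homo sapiens) for antiproliferative activity, read by MTT assay, with a stated time of 48 h; on this read-out lower numbers stand for stronger inhibition and higher numbers for weaker inhibition:
Compound 1 `CN(C)CCn1c(N)c(-c2nc3ccccc3[nH]2)c2nc(C#N)c(C#N)nc21` gives 2220 nM
Compound 2 `CCCn1c(N)c(-c2nc3ccccc3[nH]2)c2nc(C#N)c(C#N)nc21` gives 45200 nM

Compound 2 holds the higher of the two numbers (45200 nM). The change to compound 3 `CN(C)CCCn1c(N)c(-c2nc3ccccc3[nH]2)c2nc(C#N)c(C#N)nc21` is dimethylamino in place of hydrogen on a saturated chain carbon, three bonds along the chain from an aromatic nitrogen in a single place: dimethylamino in place of hydrogen on a saturated chain carbon, three bonds along the chain from an aromatic nitrogen. Going by the values given here, only one measured step bears on this, a 20-fold higher number from compound 1 to compound 2 (1.31 log units; beyond the scatter) for methyl in place of dimethylamino two bonds along the chain, large and beyond the scatter. In this assay a large step to a lower number is therefore expected, though it rests on that single pair. The step expected is an 18-fold lower number from compound 2 to compound 3 (1.26 log units; beyond the scatter) on this reading. Compound 3 is estimated at 2500 nM (expected range 800 nM to 9000 nM).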

Compound 3, half-maximal inhibitory concentration: 870 nM
Estimate against measurement, compound 3: 2.9-fold (0.46 log units) above; the measured number falls inside the stated range.
By their numbers in this assay, from the lowest: compound 3; then compound 1; then compound 2.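

In this assay, adding dimethylamino to the propyl chain, three bonds along the chain from an aromatic nitrogen, gives a 52-fold lower number from compound 2 to compound 3 (1.72 log units; beyond the scatter), so the large effect of the amine now appears at a second chain length and not in one pair alone. Going from 2-(dimethylamino)ethyl to 3-(dimethylamino)propyl gives a 2.6-fold lower number from compound 1 to compound 3 (0.41 log units; beyond the scatter), a modest step that shows chain length also counts. No available evidence explains either step.

As far as these compounds go, whether a longer chain carrying dimethylamino would lower the number further remains open. So does whether a primary amine or morpholine at the chain end would serve as well.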